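The source may report more compounds than this note shows. Statements on the series, on what has been measured and on what is new or still open speak of the compounds shown alone.

Three compounds share one core and differ only in the ring attached through the oxygen on the saturated carbon. Compound 1 `C#Cc1ccnc(O[C@@H]2CC[C@@H](C)N(C(=O)c3ccccc3-n3nccn3)C2)c1` carries a 4-ethynylpyridin-2-yl group, compound 2 `Cc1cccc(O[C@@H]2CC[C@@H](C)N(C(=O)c3ccccc3-n3nccn3)C2)n1` a 6-methylpyridin-2-yl group, and compound 3 `C[C@@H]1CC[C@@H](Oc2cc(Br)ccn2)CN1C(=O)c1ccccc1-n1nccn1` a 4-bromopyridin-2-yl group. In an assay on CHO-K1 cells for displacement of a labelled ligand from Orexin receptor type 2 (Homo sapiens), read by radioligand binding (on this read-out higher numbers stand for weaker inhibition and lower numbers for stronger inhibition), compound 1 gives 0.6 nM, compound 2 gives 7.6 nM, and compound 3 gives 1.8 nM. Compound 3 therefore stands in the middle of the three: the exchange of ethynyl for bromo shows a 3.0-fold higher number from compound 1 to compound 3 (0.48 log units; beyond the scatter), while the move from the methyl-bearing ring to the bromo-bearing ring shows a 4.2-fold lower number from compound 2 to compound 3 (0.63 log units; beyond the scatter).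

Compound 4 `C[C@@H]1CC[C@@H](Oc2ccccn2)CN1C(=O)c1ccccc1-n1nccn1` is reached from compound 3 by a single change: hydrogen in place of bromo on an aromatic carbon. Within the data shown here, no measured pair shows this exact change, but both steps above concern the same ring and both are modest yet beyond the scatter, so what sits on that ring clearly matters. With the bromo removed and nothing put in its place, a modest weakening in this assay is expected, as a step of a 2.8-fold higher number from compound 3 to compound 4 (0.44 log units; beyond the scatter). Compound 4 is accordingly estimated at 5 nM, with a likely range from 1.5 nM to 15 nM.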

Compound 4, inhibition constant: 2400 nM
Estimate against measurement, compound 4: 480-fold (2.68 log units) below; measured number outside the range, above it.
By their numbers in this assay, from the lowest: compound 1; then compound 3; then compound 2; then compound 4.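

Among these compounds, compound 4 has the plain pyridin-2-yl ring, and it shows what the earlier compounds could not: they only exchanged one group for another, whereas here the group is taken away altogether. In this assay, losing the bromo opposite the ring nitrogen gives a 1300-fold higher number from compound 3 to compound 4 (3.12 log units; beyond the scatter), and the same comparison gives a 4000-fold higher number from compound 1 to compound 4 (3.60 log units; beyond the scatter) for the ethynyl group and a 320-fold higher number from compound 2 to compound 4 (2.50 log units; beyond the scatter) for the methyl group of the 6-methylpyridin-2-yl ring, so among these four compounds the choice of group matters far less than having a group on the ring at all, with no compound going against this. The data offer no explanation for why a hydrogen in that place weakens inhibition so sharply.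

From the compounds shown here alone, it remains open whether a single fluorine or chlorine atom on the same carbon, or a methoxy or amine group there, would keep the strong inhibition seen with bromo and ethynyl. The methyl group also sits on a different ring carbon from bromo and ethynyl, so a 4-methylpyridin-2-yl ring would be needed to separate the effect of which group is present from the effect of where it sits.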